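The source may hold more compounds than are shown below. What is called first, only, known or untested is meant among the compounds shown, and "the series" means these compounds.

In a functional assay on HCT-116 cells (Homo sapiens) for cytotoxicity, read by MTT assay, with a stated time of 72 h (a higher number here means a weaker inhibitor, a lower number a stronger inhibitor), compound 1 `O=S(=O)(c1ccc(F)cc1)c1nc2ccccc2nc1N1CCCC1` gives 20600 nM, and compound 2 `Cc1ccc(S(=O)(=O)c2nc3ccccc3nc2N2CCCC(O)C2)cc1` gives 3270 nM. Compound 2 thus holds the lower number of the two, which marks it as the stronger inhibitor, and the gap between them lies beyond the usual scatter. Compound 3 `O=S(=O)(c1ccc(F)cc1)c1nc2ccccc2nc1N1CCCC(O)C1` is compound 2 with one change: fluoro in place of methyl on an aromatic carbon, para to a large group, so that 4-methylphenyl becomes 4-fluorophenyl. The two measured compounds do not differ in just one place, so they offer no direct measure of this swap. In this assay no step beyond the scatter is expected for it, and any drift is expected to be a slightly higher number. The estimated step is a 1.2-fold higher number from compound 2 to compound 3 (0.09 log units; within the scatter). The expected value for compound 3 is 4000 nM, with an estimated range from 1500 nM to 10000 nM.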

Compound 3, half-maximal inhibitory concentration: 5500 nM
The estimate for compound 3 lay 1.4-fold (0.14 log units) below the measured number; low and high end bracket the measured number.
By their numbers in this assay, from the lowest: compounds 2 and 3 (each within the scatter of the next); then compound 1.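

In this assay the swap of 4-methylphenyl for 4-fluorophenyl gives a 1.7-fold higher number from compound 2 to compound 3 (0.23 log units; within the scatter) and so gives the first direct measure at this position, where methyl and fluoro cannot be told apart. Among the compounds shown here, the one step that clears the scatter lies at the other end of the molecule: with 4-fluorophenyl held fixed, 3-hydroxypiperidin-1-yl in place of pyrrolidin-1-yl gives a 3.7-fold lower number from compound 1 to compound 3 (0.57 log units; beyond the scatter) as a modest gain. The aromatic swap therefore barely registers here, while the amine ring on the shared core has a measurable bearing on the number.

That second step changes the ring and adds the hydroxy group together, so plain piperidin-1-yl would be needed to separate the two. From the compounds shown here alone, it also remains open how a larger or charged group, such as a carboxylic acid or an amine, would fare in place of fluoro on the aromatic ring. Nothing measured here accounts for either step.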